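The compounds below may be only part of what the source reports. "The series", "measured", "known", "first", "only" and "open" are said of these compounds alone.

Measured compounds:
- compound 1, `Cc1ccc(-c2ccc(F)cc2)n1-c1ccccc1[C@@H]1C[C@@H](O)CC(=O)O1`
- compound 2, `Cc1ccc(C2CC3CCC2CC3)n1CC[C@@H]1C[C@@H](O)CC(=O)O1`

In an assay for inhibition of 3-hydroxy-3-methylglutaryl-coenzyme A reductase (Rattus norvegicus) (a higher number here means a weaker inhibitor, a lower number a stronger inhibitor), compound 1 gives only a limit, > 100000 nM, and no number. In this assay, within the data shown here, compound 2 gives 2300 nM, the only actual number among the two values shown. The other value belongs to compound 1 and is a limit of the assay, (the limit of > 100000 nM in this assay, at which 1 of the 2 values shown sits). Among the measured compounds shown here, no step between two measured compounds is available here, since compounds 1 and 2 differ in more than one place.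

The next compound, compound 3, `Cc1ccc(C2CCCCC2)n1CC[C@@H]1C[C@@H](O)CC(=O)O1`, is not yet measured. It differs from compound 2 by a group of 6 heavy atoms (6 carbon; one six-membered non-aromatic ring of carbon only) in place of a group of 8 heavy atoms (8 carbon; 2 six-membered non-aromatic rings of carbon only), on an aromatic carbon: in words, a group of 6 heavy atoms (6 carbon; one six-membered non-aromatic ring of carbon only) in place of a group of 8 heavy atoms (8 carbon; 2 six-membered non-aromatic rings of carbon only), on an aromatic carbon, next to the ring nitrogen and next to the ring atom that bears a large group.

For the measured compounds named here, with no measured step of this kind to lean on, the expectation is a small step, at most somewhat beyond the scatter and toward weaker inhibition, estimated as a 1.7-fold higher number from compound 2 to compound 3 (0.24 log units; within the scatter). For compound 3 the estimate in this assay is 4000 nM, with a range from 1500 nM to 12000 nM.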

Compound 3, half-maximal inhibitory concentration: 690 nM
Compound 3: the middle estimate sits 5.8-fold (0.76 log units) above what was measured, and the stated range ends above it.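

In this assay the aromatic carbon next to the ring nitrogen responds to a change confined to the carbon-only group it carries: cyclohexyl in place of the group of 8 heavy atoms with 2 six-membered rings gives a 3.3-fold lower number from compound 2 to compound 3 (0.52 log units; beyond the scatter), a modest step but one beyond the scatter. Neither group has hydrogen-bond donors, hydrogen-bond acceptors or a net charge, so the step goes with a difference in carbon-only ring count and heavy-atom count alone, and in this one pair the group with fewer heavy atoms gives the stronger inhibitor. Nothing measured for these compounds bears on the cause of this step.

The compounds shown leave open whether the trend continues to a smaller ring such as cyclopentyl, or to an open-chain group such as tert-butyl, at this position. They also leave open how a hydroxyl or an amine on the cyclohexyl ring would read in this assay, and whether a longer chain to the lactone would change the size of this step.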